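Thiocarbamate amides: cytotoxicity and a nitro-substituted analogue

This account rests on a few compounds, and the source may have more. Where it says the series, first, only, none or still open, it means among the compounds named here.

Measured compounds:
- compound 1 `Cc1ccc(C(=O)N(C(=S)OCCN2C(=O)c3ccccc3C2=O)c2ccc(C)cc2)cc1` gives 83000 nM
- compound 2 `O=C1c2ccccc2C(=O)N1CCOC(=S)N(C(=O)c1cccc(F)c1F)c1ccc(Cl)cc1` gives 58000 nM

Both compounds were read in an ADME assay on MT4 cells (Homo sapiens) for cytotoxicity, read by MTT assay; a higher number here means that more compound is tolerated, a lower number that less compound is tolerated. Compound 2 has the lowest of the two numbers shown, but its nearest neighbour is compound 1, whose number sits only slightly higher, within the scatter of repeated measurements; nothing separates the two in this assay.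

The step of interest leads from compound 2 to compound 3 `O=C1c2ccccc2C(=O)N1CCOC(=S)N(C(=O)c1ccc(Cl)c([N+](=O)[O-])c1)c1ccc(Cl)cc1`, which has not yet been measured. The change is confined to one place: 4-chloro-3-nitrophenyl in place of 2,3-difluorophenyl on a carbonyl carbon. The rest of the molecule, including the shared core, is unchanged.

Among the measured compounds shown here, no step between measured compounds is available to guide the size of this change, and the two numbers that exist lie within the scatter of each other. The expectation for compound 3 is therefore a step of a 1.2-fold lower number from compound 2 to compound 3 (0.06 log units; within the scatter) in this assay, that is, nothing beyond the scatter, with no firm direction. Compound 3 is expected to give about 50000 nM, with a plausible range from 20000 nM to 130000 nM.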

Compound 3, half-maximal cytotoxic concentration: 48000 nM
Beside the measured number, compound 3's estimate is 1.0-fold (0.02 log units) above it; the range from low to high includes it.
By their numbers in this assay, from the lowest: compounds 3, 2 and 1 (each within the scatter of the next).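

Among the compounds shown here, replacing 2,3-difluorophenyl with 4-chloro-3-nitrophenyl on the carbonyl carbon gives the first step that can be read at this position: in this assay there is a 1.2-fold lower number from compound 2 to compound 3 (0.08 log units; within the scatter), so the two compounds cannot be told apart. The earlier pair could not show this, as compound 1 and compound 2 differ in more than one place; here a single change, to a group with more heavy atoms and with hydrogen-bond acceptors that the departing group lacks, leaves the result inside the scatter of repeated measurements. No measured property of these groups is available that could account for the result or give it a cause.

Going by these compounds, whether a group of another kind on this carbonyl carbon, such as a morpholine, a carboxylic acid or a longer alkyl chain, would give a step beyond the scatter remains open. Also open, on these data alone, is whether the number in this assay depends mainly on the shared core rather than on the group at this position.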